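The source may hold more compounds than are shown below. What is called first, only, known or untested is meant among the compounds shown, and "the series" means these compounds.

Working notes on the series. In a functional assay on COLO 205 cells (Homo sapiens) for inhibition, read by sulforhodamine B assay, with a stated time of 48 h, tested at 50 uM (on this read-out lower numbers stand for less inhibition of growth and higher numbers for more inhibition of growth at the one concentration tested), compound 1 (`COc1cc(/C=C/C(=O)/C=C/c2ccccc2)ccc1OCc1cn(CCCCOc2cc(=O)oc3ccccc23)nn1`) gives 31% and compound 2 (`COc1cccc(/C=C/C(=O)/C=C/c2ccc(OCc3cn(CCOc4cc(=O)oc5ccccc45)nn3)c(OC)c2)c1`) gives 69%. Going by the values given here, compound 1 therefore stands as the lower of only two numbers, and its gap to compound 2 lies beyond the usual scatter. Among the compounds with values here, no pair of measured compounds differs in just one place, so the size of a single change has not yet been seen.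

Compound 3 (`COc1cc(/C=C/C(=O)/C=C/c2cccs2)ccc1OCc1cn(CCCCOc2cc(=O)oc3ccccc23)nn1`) has not yet been measured. It departs from compound 1 in one place: thiophen-2-yl in place of phenyl on a double-bonded chain carbon bound to a double-bonded chain carbon. The rest of the structure of compound 1 is kept. Within the data shown here, with no single-place step to draw on, the expectation in this assay is for no step beyond the scatter, with a slight lean upward. The estimated step is a number 4 percentage points higher from compound 1 to compound 3 (within the scatter). The range stays wide: compound 2 at 69% shows that members of this series can sit far from compound 1. For compound 3 the expected value is 35%, with an estimated range of 18% to 55%.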

Compound 3, percent growth inhibition at one concentration: 40%
Compound 3: middle estimate off by 5 percentage points, on the low side; the range from low to high includes it.
By their numbers in this assay, from the lowest: compounds 1 and 3 (each within the scatter of the next); then compound 2.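

In this assay the series now has its first single-place step, and thiophen-2-yl in place of phenyl on a double-bonded chain carbon bound to a double-bonded chain carbon gives a number 9 percentage points higher from compound 1 to compound 3 (within the scatter) in this pair. At this position, therefore, a five-membered aromatic ring with 1 hetero atom and a six-membered aromatic ring of carbon only cannot be told apart on this read-out, and compound 1 and compound 3 cannot be put in order. No measurement here bears on why the step has this size.

Going by these compounds alone, the single step also says nothing about what separates compound 2 from compound 1, as those two differ in more than one place and no step between them can be read. Still open, from the compounds shown here alone, is whether furan-2-yl, pyridin-3-yl or a phenyl ring carrying a dimethylamino group at this same position would stay within the scatter of compound 1 or move clearly away from it.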